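The compounds below may be only part of what the source reports. "The series", "measured", "known", "first", "only" and "open" are said of these compounds alone.

Compound 3 `Cc1nn(-c2ncnc3nc[nH]c23)c2c1C(OCc1ccccc1F)CC(=O)N2` is one of three compounds built on the same core, differing only in the group attached to a saturated ring carbon. In a functional assay on HEK293 cells for agonist activity at G-protein coupled receptor 39 (Homo sapiens), read by scintillation proximity assay and inositol phosphate accumulation, with a stated time of 75 min, in the presence of a further agent that is not named here (a lower number here means that less compound is needed, a higher number that more compound is needed for the effect), compound 3 gives 4 nM, level with compound 1 `Cc1nn(-c2ncnc3nc[nH]c23)c2c1C(OCc1ccc(Cl)cc1Cl)CC(=O)N2` at 4 nM, while compound 2 `Cc1nn(-c2ncnc3nc[nH]c23)c2c1C(OC1CCCC1)CC(=O)N2` gives 2 nM. The steps of no change at the digits printed from compound 1 to compound 3 (within the scatter) and a 2.0-fold higher number from compound 2 to compound 3 (0.30 log units; within the scatter) both lie within the scatter, so these three groups at that carbon behave alike. Compound 4 `Cc1nn(-c2ncnc3nc[nH]c23)c2c1C(C(=O)NCc1ccccc1)CC(=O)N2` carries benzylcarbamoyl in place of (2-fluorobenzyl)oxy on a saturated ring carbon. For the measured compounds named here, none of the measured steps touches the oxygen itself, so they offer no direct guide. The expected step of a 2.5-fold higher number from compound 3 to compound 4 (0.40 log units; beyond the scatter) is therefore a cautious guess toward a somewhat higher number. Compound 4 is estimated at 10 nM, with a range from 2 nM to 60 nM.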

Compound 4, half-maximal effective concentration: 5 nM
Compound 4: the middle estimate sits 2.0-fold (0.30 log units) above what was measured, within the range that was stated.
By their numbers in this assay, from the lowest: compounds 2, 1, 3 and 4 (each within the scatter of the next, the first and the last beyond it).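

The oxygen on this saturated ring carbon can give way to benzylcarbamoyl, which brings a carbonyl and an amide hydrogen, with a 1.3-fold higher number from compound 3 to compound 4 (0.10 log units; within the scatter) and a 1.3-fold higher number from compound 1 to compound 4 (0.10 log units; within the scatter) in this assay. Only the comparison with the cyclopentyloxy group goes beyond the usual variation, and modestly, with a 2.5-fold higher number from compound 2 to compound 4 (0.40 log units; beyond the scatter). Nothing available here explains these results. The compounds shown leave open whether the amide hydrogen matters to the effect. They also leave open how a carboxylic acid or a primary amine on this carbon would compare.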